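Shrinking the ring on the sulfonamide side chain

The source may hold more compounds than are shown below. What is called first, only, known or untested is meant among the compounds shown, and "the series" means these compounds.

Measured so far:
- compound 1, `NC(=O)[C@@H](CCC(F)(F)F)N(CC1CCCC1)S(=O)(=O)c1ccc(Cl)cc1`: 5.15
- compound 2, `NC(=O)[C@@H](CCC(F)(F)F)N(C[C@H]1CCCCO1)S(=O)(=O)c1ccc(Cl)cc1`: 4.3
- compound 3, `NC(=O)[C@@H](CCC(F)(F)F)N(C[C@@H]1CCOC1)S(=O)(=O)c1ccc(Cl)cc1`: 2.8

These three compounds were measured in a physicochemical assay for lipophilicity, read by HPLC, measured as octanol-water partition, at pH 7.4; on this read-out lower numbers stand for lower lipophilicity and higher numbers for higher lipophilicity. Compound 2 stands second highest of the three: compound 1 lies a number 0.85 log units lower from compound 1 to compound 2 (beyond the scatter) above it, and compound 3 lies a number 1.50 log units lower from compound 2 to compound 3 (beyond the scatter) below it. The largest step seen is a number 2.35 log units lower from compound 1 to compound 3 (beyond the scatter).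

Compound 4, `NC(=O)[C@@H](CCC(F)(F)F)N(C[C@H]1CCO1)S(=O)(=O)c1ccc(Cl)cc1`, has not yet been measured. It differs from compound 2 in one place: oxetan-2-yl in place of oxan-2-yl on a saturated chain carbon bound to a sulfonamide nitrogen

Among the measured compounds shown here, the step that bears most directly on this change is the one from compound 2 to compound 3, where a smaller ring with one oxygen replaced oxan-2-yl and the reading dropped by a number 1.50 log units lower from compound 2 to compound 3 (beyond the scatter). Oxetan-2-yl is smaller still than oxolan-3-yl, so a drop of comparable or somewhat smaller size is expected in this assay. The expected step is a number 1.20 log units lower from compound 2 to compound 4 (beyond the scatter). For compound 4 the estimate in this assay is 3.1, within a range from 2.4 to 3.8.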

Compound 4, distribution coefficient: 2.6
Compound 4: the middle estimate sits 0.50 log units above what was measured, within the range that was stated.
By their numbers in this assay, from the lowest: compounds 4 and 3 (each within the scatter of the next); then compound 2; then compound 1.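

In this assay, the four-membered ring gives a drop of its own size: a number 1.70 log units lower from compound 2 to compound 4 (beyond the scatter), and against the carbocycle the change is a number 2.55 log units lower from compound 1 to compound 4 (beyond the scatter). The new step of a number 0.20 log units lower from compound 3 to compound 4 (within the scatter) shows that oxetan-2-yl and oxolan-3-yl cannot be told apart on this read-out, so at this position the reading does not keep following ring size once the ring is smaller than oxan-2-yl. Compound 2 therefore stands apart from both smaller oxygen rings, while compounds 3 and 4 share one level despite their different rings.

On these data alone, whether oxolan-2-yl, oxetan-3-yl or a ring carrying an amine would read at that same level stays open. Nothing available explains why the reading falls between compound 2 and the two smaller rings.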